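Benzyl Substituent Effects on Cytotoxicity of a Brominated Core

The source may report more compounds than this note shows. Statements on the series, on what has been measured and on what is new or still open speak of the compounds shown alone.

Compound 1: `CC1(C)OC2O[C@@H](Cc3cn4cc(Cl)ccc4nc3=O)C(OCc3ccccc3)C2O1` — > 1000000 nM
Compound 2: `O=c1nc2ccc(Br)cn2cc1Cc1ccccc1` — 152000 nM

Of the compounds shown here, two have been measured in a functional assay on HeLa cells (Homo sapiens) for cytotoxicity, read by MTT assay, with a stated time of 24 h; on this read-out higher numbers stand for weaker inhibition and lower numbers for stronger inhibition. For compound 1 the value of > 1000000 nM is a limit of the assay and not a number, which is noted as the limit of > 1000000 nM in this assay, at which 1 of the 2 values shown sits. Among the measured compounds shown here, compound 2 is the only compound for which an actual number is known, and in this assay compound 2 gives 152000 nM, a weak effect.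

Compound 3, `O=c1nc2ccc(Br)cn2cc1Cc1ccc(Cl)cc1`, is not yet measured. It differs from compound 2 in one place: chloro in place of hydrogen on an aromatic carbon. For the measured compounds named here, no measured pair in this set isolates such a change, so there is nothing here that shows how this chloro group shifts the read-out. Given the weak activity of compound 2 and the small size of the change, compound 3 is expected to stay close to compound 2, with a step of a 1.4-fold lower number from compound 2 to compound 3 (0.14 log units; within the scatter) that is not expected to exceed the usual scatter. Compound 3 is therefore estimated at 110000 nM, with a range from 35000 nM to 400000 nM.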

Compound 3, half-maximal inhibitory concentration: > 1000000 nM
Compound 3 ended at the assay's limit (the forecaster's own chance of this, stated with the estimate: 10%); middle value at least 9.0-fold (0.95 log units) from the limit.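

In this assay, chloro in place of hydrogen on an aromatic carbon, para to a large group, gives an at least 6.5-fold higher number from compound 2 to compound 3 (0.81 log units; beyond the scatter). Among the compounds shown here, this is the first step that isolates a single change, and it shows that this position on the six-membered aromatic ring of carbon only is not indifferent: one added chlorine atom moves the read-out towards weaker inhibition, by more than the usual scatter. The value of compound 3 is a limit and not a number, so the step has a lower bound but no upper one, and its full size cannot be read: the limit of > 1000000 nM in this assay, at which 2 of the 3 values shown sit.

The compounds shown leave open whether a fluoro group, a methoxy group or an amine on this carbon would shift the read-out in the same way, or whether the shift belongs to chloro alone. For the compounds shown here, compound 1 differs from compound 2 and compound 3 in more than one place, so it offers no step to set beside this one, and whether the effect of chloro carries over to another core also stays open.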